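Series notes: cytotoxicity of aryl variants at the pyridine-type carbon

The source may hold more compounds than are shown below. What is called first, only, known or untested is meant among the compounds shown, and "the series" means these compounds.

Compound 3 `Cc1nn(-c2ccccc2)c2nc(-c3ccc(C(F)(F)F)cc3)c(C#N)c(-c3ccccc3O)c12` is the reference point here. In an ADME assay on BJ cells (Homo sapiens) for cytotoxicity, with a stated time of 72 h (a lower number here means that less compound is needed, a higher number that more compound is needed for the effect), compound 3 gives 22900 nM. The neighbouring analogue compound 2 `Cc1ccc(-c2nc3c(c(C)nn3-c3ccccc3)c(-c3ccccc3O)c2C#N)cc1` gives 22200 nM in this assay, and the two sit within the scatter of each other, a 1.0-fold higher number from compound 2 to compound 3 (0.01 log units; within the scatter). The remaining member, compound 1 `COc1cccc(-c2nc3c(c(C)nn3-c3ccccc3)c(-c3ccccc3O)c2C#N)c1`, returns only a limit in this assay, > 23000 nM, so its number is not known. Among the compounds with values here, the step of a number no higher from compound 1 to compound 3 (the limit leaves the size open) is therefore of open size, as is an at least 1.0-fold lower number from compound 1 to compound 2 (0.01 log units; that floor lies within the scatter); the one piece of evidence on these steps is the limit of > 23000 nM in this assay, at which 1 of the 3 values shown sits.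

Compound 4 `CCc1cccc(-c2nc3c(c(C)nn3-c3ccccc3)c(-c3ccccc3O)c2C#N)c1` is not yet measured in this assay. It differs from compound 3 by the change (3-ethylphenyl in place of 4-(trifluoromethyl)phenyl on an aromatic carbon).

The measured steps that bear on this are the aryl swaps already made: 3-methoxyphenyl to 4-methylphenyl, 3-methoxyphenyl to 4-(trifluoromethyl)phenyl, and methyl to trifluoromethyl, none of which moved the number beyond the scatter, and all three compounds sit near the upper end of the assay. The exchange for 3-ethylphenyl is expected to behave the same way, with the step of a 1.0-fold higher number from compound 3 to compound 4 (0.00 log units; within the scatter) staying within the scatter. Compound 4 is thus estimated at 23000 nM, with a range from 14000 nM to 32000 nM, and a fair chance that only a limit is reported.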

Compound 4, half-maximal effective concentration: > 20000 nM
Compound 4: only a limit was reported; the forecaster's own chance of this, stated with the estimate: 45%; the middle value is on the limit's open side.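

In this assay compound 4 returns only a limit, > 20000 nM. Its steps from compound 1, compound 2 and compound 3 therefore cannot be read: the limit of > 20000 nM in this assay, at which 1 of the 4 values shown sits.

The compounds shown leave open where the numbers of compound 1 and compound 4 lie, and whether any aryl exchange at this carbon moves the number in this assay beyond the scatter.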